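Formyl in Place of Chlorobenzyloxy on the Shared Core

The source may report more compounds than this note shows. Statements on the series, on what has been measured and on what is new or still open speak of the compounds shown alone.

Compound 1, `CC(O)(c1ccccc1)c1c(-c2ccccc2)c(-c2ccccc2)n2ccc(C#N)cc12`: compound 1 gives "not determined" (no result reported) in an assay for inhibition of Polyunsaturated fatty acid lipoxygenase ALOX15 (Oryctolagus cuniculus); a higher number here means a weaker inhibitor, a lower number a stronger inhibitor.
Compound 2, `N#Cc1ccn2c(-c3ccccc3)c(-c3ccccc3)c(Cc3ccccc3)c2c1`: compound 2 gives 46000 nM in this assay.
Compound 3, `N#Cc1ccn2c(-c3ccccc3)c(-c3ccccc3)c(OCc3ccc(Cl)cc3)c2c1`: compound 3 gives "not determined" (no result reported) in this assay.

Of the three compounds made so far, only compound 2 comes with a number, and that number places it among weak inhibitors in this assay. Compound 3 stands without a number of its own, as does compound 1, so nothing can yet be said about how compound 3 compares with compound 2 in this assay.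

The next compound, compound 4, `N#Cc1ccn2c(-c3ccccc3)c(-c3ccccc3)c(C=O)c2c1`, keeps the shared core of compound 3 and changes one group: formyl in place of (4-chlorobenzyl)oxy on an aromatic carbon. Among the measured compounds shown here, no measured pair shows what such a swap does in this assay, so the size and direction of this step cannot be read from the data; it may be small, within the scatter, or large in either direction.

The only anchor is the weak result of compound 2 in this assay, which carries a different group at the same place. On that basis compound 4 is expected to land in the same weak region, with a wide range: an estimated 40000 nM, between 8000 nM and 200000 nM, in this assay.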

Compound 4, half-maximal inhibitory concentration: 61000 nM
Estimate against measurement, compound 4: 1.5-fold (0.18 log units) below; low and high end bracket the measured number.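

In this assay, formyl in place of benzyl on this aromatic carbon gives a 1.3-fold higher number from compound 2 to compound 4 (0.12 log units; within the scatter), so these two groups cannot be told apart at this position, although benzyl brings a carbon ring and formyl has no ring and only 2 heavy atoms; both compounds remain weak inhibitors. Compound 3 has no number, so the change from (4-chlorobenzyl)oxy to formyl cannot be read, and the result says nothing about how the oxygen-linked group behaves. The data offer no independent information on why benzyl and formyl give such similar readings.

On these data alone, two groups are a narrow sample of this position, so it remains open whether it is generally insensitive to what it carries or whether a different kind of group, such as an amine, a carboxylic acid or a longer chain, would move the number well beyond the scatter. The compounds shown also keep both phenyl groups and the nitrile unchanged, which leaves the contribution of those parts of the shared core unknown.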